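From thiophen-2-yl to benzyloxy on a carbonyl carbon

The compounds below may be only part of what the source reports. "The series", "measured", "known", "first", "only" and "open" are said of these compounds alone.

Values in a functional assay on L5178Y cells (Mus musculus) for inhibition, read by MTT assay, with a stated time of 24 h (a higher number here means a weaker inhibitor, a lower number a stronger inhibitor), are as follows.

Compound 1 `COc1cccc(/C=N/N=C2\C[C@@H](c3ccc(O)cc3)Oc3cc(OC)cc(O)c32)c1` – >= 11300 nM (a limit)
Compound 2 `O=C(N/N=C1\C[C@@H](c2ccc(O)cc2)Oc2cc(O)cc(O)c21)c1cccs1` – >= 11300 nM (a limit)
Compound 3 `COc1cc(O)c2c(c1)O[C@H](c1ccc(O)cc1)C/C2=N\NC(=O)c1cccs1` – 9400 nM

In this assay, among the measured compounds shown here, compound 3 gives 9400 nM, the only actual number in the set. For compound 1 and compound 2 there is only (the limit of >= 11300 nM in this assay, at which 2 of the 3 values shown sit), with no number behind it.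

Compound 4 `COc1cc(O)c2c(c1)O[C@H](c1ccc(O)cc1)C/C2=N\NC(=O)OCc1ccccc1` has not yet been measured. Compared with compound 3 it carries benzyloxy in place of thiophen-2-yl on a carbonyl carbon, that is, benzyloxy in place of thiophen-2-yl on a carbonyl carbon.

For the measured compounds named here, no measured step makes this exact change. The nearest guide is the exchange of the group on a double-bonded nitrogen, an at least 1.2-fold lower number from compound 1 to compound 3 (0.07 log units; that floor lies within the scatter), which includes the thiophen-2-yl ring. The other measured step, an at least 1.2-fold lower number from compound 2 to compound 3 (0.07 log units; that floor lies within the scatter), is a change of methyl in place of hydrogen on an oxygen on an aromatic ring, elsewhere in the molecule. Both start from a limit, and neither shows a step beyond the scatter.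

In this assay no change beyond the scatter is therefore expected, with the estimated step being a 1.0-fold higher number from compound 3 to compound 4 (0.00 log units; within the scatter) in size. Compound 4 is estimated at 9500 nM, with an expected range from 4500 nM to 20000 nM for its measurement.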

Compound 4, half-maximal inhibitory concentration: >= 11300 nM
Compound 4: a limit, no number; the forecaster's own chance of this, stated with the estimate: 35%; middle value at least 1.1-fold (0.07 log units) away from the limit.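

Among the compounds shown here, at this position, on a carbonyl carbon whose other neighbour is an amide-type nitrogen, the exchange of thiophen-2-yl for benzyloxy gives the first direct reading of the group on that carbonyl, with the rest of the molecule unchanged: in this assay the reading is an at least 1.2-fold higher number from compound 3 to compound 4 (0.07 log units; that floor lies within the scatter). In this assay compound 4 gives >= 11300 nM, which is a limit and not a number. The floor of this step lies within the scatter, which means that the result does not establish a real loss on going to benzyloxy, and the set as a whole now gathers at one ceiling, with compound 3 the only member that has an actual number: the limit of >= 11300 nM in this assay, at which 3 of the 4 values shown sit.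

On these data alone, how far compound 4 truly lies from compound 3 stays open, as does whether any group on this carbonyl carbon can give a step beyond the scatter. The compounds shown also do not tell how an amine such as dimethylamino, a carboxylic acid or a longer alkyl chain would read at this place in place of thiophen-2-yl or benzyloxy.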